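A few compounds are considered here, and "the series" means these few. Any claim that something is new, unique, unknown or untested is made for them only; others in the source may bear on it.

Among the compounds with values here, compound 1 `CC1(C)N=C(N)N=C(N)N1c1cccc(CNC(=O)N2CCOCC2)c1` stands lowest of the two measured members. In an assay on isolated protein for inhibition of Dihydrofolate reductase (Mus musculus) (a lower number here means a less potent compound, a higher number a more potent compound, by a factor of ten per unit of this negative logarithm), compound 1 gives 6.43, while compound 2 `CC1(C)N=C(N)N=C(N)N1c1ccc(CCCCc2cccc(Cl)c2S(=O)(=O)F)c(Cl)c1` gives 8.2, a gap well beyond the usual scatter; the two structures differ in many places, so the gap cannot be tied to any one change. Compound 3 `COc1cccc(NC(=O)NCc2cccc(N3C(N)=NC(N)=NC3(C)C)c2)c1` is the next member. It differs from compound 1 in a single place ((3-methoxyphenyl)amino in place of morpholin-4-yl on a carbonyl carbon). Within the data shown here, no measured pair shows this change. A modest gain is expected, a number 0.47 log units higher from compound 1 to compound 3 (beyond the scatter). For compound 3 the estimate is 6.9, with a range from 6 to 7.7.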

Compound 3, logarithm of the reciprocal of the active concentration, log(1/C): 8.02
The estimate for compound 3 lay 1.12 log units below the measured number, outside the stated range (above it).
By their numbers in this assay, from the lowest: compound 1; then compounds 3 and 2 (each within the scatter of the next).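

On the carbonyl carbon whose other neighbour is the amide-type nitrogen, replacing morpholin-4-yl with (3-methoxyphenyl)amino gives, in this assay, a step of a number 1.59 log units higher from compound 1 to compound 3 (beyond the scatter). Within the data shown here, this is the first single-place comparison, and it shows that this position strongly affects the read-out. No available data explain the size of the step. The change swaps the non-aromatic ring for an aromatic one, adds a hydrogen-bond donor and brings in a methoxy group, so these features remain confounded. Phenylamino or cyclohexylamino on the same carbonyl carbon would begin to separate them.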